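The compounds below may be only part of what the source reports. "The series", "measured", "known", "first", "only" and "open" are said of these compounds alone.

Series notes. The shared core carries an ethyl-linked phenyl ring whose terminal group varies. Compound 1 `CCC(C)(C)Cc1c[nH]c(CCc2ccc(-c3ccccc3O)cc2)n1` bears a 2-hydroxyphenyl group and in a functional assay for agonist activity at Bombesin receptor subtype-3 (Homo sapiens) (a lower number here means that less compound is needed, a higher number that more compound is needed for the effect), compound 1 gives 133 nM. Compound 2 `CCC(C)(C)Cc1c[nH]c(CCc2ccc(N3CCCC[C@@H]3C(=O)O)cc2)n1` carries a 2-carboxypiperidin-1-yl group instead, and in this assay compound 2 gives 24 nM, a step of a 5.5-fold lower number from compound 1 to compound 2 (0.74 log units; beyond the scatter). Compound 3 `CCC(C)(C)Cc1c[nH]c(CCc2ccc(N3CCCC[C@@H]3c3nnn[nH]3)cc2)n1` replaces carboxy with 1H-tetrazol-5-yl on the saturated ring carbon; in this assay compound 3 gives 15 nM, a step of a 1.6-fold lower number from compound 2 to compound 3 (0.20 log units; within the scatter). Compound 3 therefore holds the lowest number of the three, with compound 2 within the scatter of it and compound 1 clearly higher.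

Compound 4 `CCC(C)(C)Cc1c[nH]c(CCc2ccc(N3CCCC[C@@H]3c3ncn[nH]3)cc2)n1` differs from compound 3 only in the change (1H-1,2,4-triazol-5-yl in place of 1H-tetrazol-5-yl on a saturated ring carbon). Among the measured compounds shown here, the one measured step that bears on exchanging the group at this saturated ring carbon, a 1.6-fold lower number from compound 2 to compound 3 (0.20 log units; within the scatter), stayed within the scatter, and no other step touches this position. Compound 4 is accordingly expected to stay close to compound 3 in this assay, with a step of a 1.7-fold higher number from compound 3 to compound 4 (0.22 log units; within the scatter). The estimate for compound 4 is 25 nM, within the range 9 nM to 70 nM.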

Compound 4, half-maximal effective concentration: 42 nM
Estimate against measurement, compound 4: 1.7-fold (0.23 log units) below; measured number inside the range.
By their numbers in this assay, from the lowest: compounds 3, 2 and 4 (each within the scatter of the next, the first and the last beyond it); then compound 1.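

The exchange at this saturated ring carbon now gives a step beyond the scatter: in this assay there is a 2.8-fold higher number from compound 3 to compound 4 (0.45 log units; beyond the scatter), so this position does distinguish between two uncharged five-membered aromatic rings that each keep 1 hydrogen-bond donor. Set against the carboxy group, the same new ring gives a 1.8-fold higher number from compound 2 to compound 4 (0.24 log units; within the scatter), which stays within the scatter, so only the pair of ring groups, compound 3 and compound 4, is separated here. Nothing available explains why the 1H-1,2,4-triazol-5-yl and 1H-tetrazol-5-yl groups part in this way.

Still open, as far as these compounds go, is how a primary amide, a hydroxymethyl group or an amine at this ring carbon would compare with these three groups. The shown compounds also leave open whether the opposite configuration at this carbon would keep these numbers.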